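Swapping the anilide ring: chloro for ethyl

The compounds below may be only part of what the source reports. "The series", "measured", "known", "first", "only" and "open" are said of these compounds alone.

For the measured compounds named here, compound 1 `CCc1cccc(NC(=O)c2cccc(/C=C3\CC(=O)N(Cc4ccccc4)C3=O)c2)c1` stands at the highest of the three numbers measured so far in an ADME assay on SW480 cells (Homo sapiens) for cytotoxicity, read by MTT assay, with a stated time of 72 h (on this read-out higher numbers stand for weaker inhibition and lower numbers for stronger inhibition), where compound 1 gives 91500 nM. Its neighbours differ from it only at the amide-type nitrogen in the ring of the shared core: compound 2 `CCc1cccc(NC(=O)c2cccc(/C=C3\CC(=O)N(c4ccccc4)C3=O)c2)c1` gives 88600 nM and compound 3 `CCCCCN1C(=O)C/C(=C\c2cccc(C(=O)Nc3cccc(CC)c3)c2)C1=O` gives 83300 nM. The steps of a 1.0-fold lower number from compound 1 to compound 2 (0.01 log units; within the scatter), a 1.1-fold lower number from compound 1 to compound 3 (0.04 log units; within the scatter) and a 1.1-fold lower number from compound 2 to compound 3 (0.03 log units; within the scatter) all stay within the scatter, so these three compounds cannot be told apart on this read-out.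

Compound 4 `O=C(Nc1ccc(Cl)cc1)c1cccc(/C=C2\CC(=O)N(Cc3ccccc3)C2=O)c1` alters a different part of compound 1: 4-chlorophenyl in place of 3-ethylphenyl on an amide-type nitrogen. Going by the values given here, none of the measured steps touches this amide-type nitrogen; all of them concern the nitrogen in the ring, and none of them moved the number. Among the compounds with values here, no step in this assay therefore bears directly on this change, and the only guide is that the series so far sits in a narrow band. The step expected in this assay is a 1.0-fold lower number from compound 1 to compound 4 (0.01 log units; within the scatter), none beyond the scatter. Compound 4 is estimated at 90000 nM in this assay, within a range from 40000 nM to 200000 nM.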

Compound 4, half-maximal inhibitory concentration: > 100000 nM
Compound 4: a limit, no number (the forecaster's own chance of this, stated with the estimate: 10%); middle value at least 1.1-fold (0.04 log units) away from the limit.
By their numbers in this assay, from the lowest: compounds 3, 2 and 1 (each within the scatter of the next). At a limit, above all of these: compound 4.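

Compound 4 is the only compound shown with a change at the amide-type nitrogen outside the ring, and its reading is a limit, not a number: the limit of > 100000 nM in this assay, at which 1 of the 4 values shown sits. In this assay, on these data alone, this gives an at least 1.0-fold higher number from compound 1 to compound 4 (0.03 log units; that floor lies within the scatter), which is only a floor, so the change cannot yet be said to have moved the number, and how far compound 4 really lies from compound 1 stays unknown. Because both the group and the number in its name change when 4-chlorophenyl replaces 3-ethylphenyl, this single step cannot separate the two changes.

As far as these compounds go, it remains open whether a methoxy group, an amine or a carboxylic acid on this phenyl ring would give a measurable number. From the compounds shown here alone, it is also open whether any change here would shift the reading beyond the usual scatter.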